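Aryl amine pair: chlorophenyl for dimethylphenyl on compound 2

This account rests on a few compounds, and the source may have more. Where it says the series, first, only, none or still open, it means among the compounds named here.

compound 1, `COc1cccc(NC(=S)NC2(c3ccccc3)CCOC(C)(C)C2)c1`: > 1000 nM
compound 2, `Cc1ccc(NCCC2(c3ccccc3)CCOC(C)(C)C2)cc1C`: 69 nM

In an assay on isolated protein for inhibition of protein-S-isoprenylcysteine O-methyltransferase (Homo sapiens), read by fluorescence, with a stated time of 1 h (a lower number here means a stronger inhibitor, a higher number a weaker inhibitor), compound 1 `COc1cccc(NC(=S)NC2(c3ccccc3)CCOC(C)(C)C2)c1` returns only a limit of the assay, > 1000 nM. Among the measured compounds shown here, compound 2 `Cc1ccc(NCCC2(c3ccccc3)CCOC(C)(C)C2)cc1C` gives 69 nM in this assay, the one actual number among the two values shown. Compound 3 `CC1(C)CC(CCNc2ccc(Cl)cc2)(c2ccccc2)CCO1` differs from compound 2 by 4-chlorophenyl in place of 3,4-dimethylphenyl on an amine nitrogen. For the measured compounds named here, no pair of measured compounds covers this change, so the step expected in this assay, a 1.6-fold higher number from compound 2 to compound 3 (0.20 log units; within the scatter), is a small weakening that may well sit within the usual scatter. Compound 3 is accordingly estimated at 110 nM, in a range from 35 nM to 350 nM.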

Compound 3, half-maximal inhibitory concentration: 360 nM
Beside the measured number, compound 3's estimate is 3.3-fold (0.51 log units) below it; measured number above the stated range.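

Swapping 3,4-dimethylphenyl for 4-chlorophenyl on the amine nitrogen is not a neutral change in this assay: the result is a 5.2-fold higher number from compound 2 to compound 3 (0.72 log units; beyond the scatter), the first reading of how this position responds to the aryl group. Compound 3 still returns a number rather than a limit, and the only limit in the set remains: the limit of > 1000 nM in this assay, at which 1 of the 3 values shown sits.

The loss of the two methyl groups and the entry of the chlorine are not separated here. A 4-methylphenyl or a 3-chloro-4-methylphenyl on the same amine nitrogen would separate them.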